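Thiosemicarbazone series: nitro to methoxy on the aryl ring

The source may hold more compounds than are shown below. What is called first, only, known or untested is meant among the compounds shown, and "the series" means these compounds.

Two members of the series have been measured so far. Compound 1 `O=[N+]([O-])c1cccc(/C=N\NC(=S)NC2CCCCC2)c1` gives 84800 nM in a functional assay on MDA-MB-231 cells (Homo sapiens) for inhibition, read by WST assay, with a stated time of 48 h; a lower number here means a stronger inhibitor, a higher number a weaker inhibitor. Compound 2 `O=[N+]([O-])c1ccccc1/C=N\NC(=S)NC1CCCCC1` gives 118000 nM in this assay. Compound 1 holds the lowest of the two numbers, but compound 2 stands within the usual scatter of it, so the two values cannot be ordered.

Compound 3 `COc1cccc(/C=N\NC(=S)NC2CCCCC2)c1` has not been measured in this assay. It differs from compound 1 in one place: methoxy in place of nitro on an aromatic carbon. Within the data shown here, no step between measured compounds touches this position, so the direction of the change has no precedent here. Given that both measured compounds sit close together, no step beyond the scatter is expected from compound 1 to compound 3; the estimated shift is a 1.1-fold higher number from compound 1 to compound 3 (0.03 log units; within the scatter). Compound 3 is therefore expected to give about 90000 nM in this assay, within a range of 30000 nM to 270000 nM.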

Compound 3, half-maximal inhibitory concentration: 88900 nM
Compound 3: the middle estimate sits 1.0-fold (0.01 log units) above what was measured; the range from low to high includes it.
By their numbers in this assay, from the lowest: compounds 1, 3 and 2 (each within the scatter of the next).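

Methoxy in place of nitro on an aromatic carbon, meta to a large group, is the first exchange of this series read at this position. In this assay it gives a 1.0-fold higher number from compound 1 to compound 3 (0.02 log units; within the scatter) and so lies within the scatter. Nitro is therefore not needed at this position to keep the number at the level of compound 1, and a group with one heavy atom fewer and no double bond outside the aromatic ring serves equally in this assay. No measurement of any property of the two groups is at hand to interpret this result.

Still open, as far as these compounds go, is whether any group at this position moves the number beyond the scatter, such as an amine, a carboxylic acid or a longer alkoxy chain. Also open, from the compounds shown here alone, is whether methoxy reads the same way at the place that nitro holds in compound 2.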